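Trimming the tetramethylbutyl tail of an aryloxyacetamide

The source may report more compounds than this note shows. Statements on the series, on what has been measured and on what is new or still open speak of the compounds shown alone.

The measured compounds and their numbers:
- compound 1, `CC(C)(C)CC(C)(C)c1ccc(OCC(=O)Nc2ccc(C(F)(F)F)cc2)cc1`: 1530 nM
- compound 2, `COCCOc1ccc(C(=O)OC)cc1NC(=O)COc1ccc(C(C)(C)CC(C)(C)C)cc1`: 29000 nM
- compound 3, `COC(=O)c1cccc(NC(=O)COc2ccc(C(C)(C)CC(C)(C)C)cc2)c1`: 8920 nM

All three were tested in an assay on isolated protein for inhibition of malate dehydrogenase, mitochondrial (Homo sapiens), with a stated time of 30 min; on this read-out higher numbers stand for weaker inhibition and lower numbers for stronger inhibition. Compound 3 stands second highest of the three numbers, with 8920 nM. Its nearest neighbour is compound 2, which differs in one place; the step of a 3.3-fold lower number from compound 2 to compound 3 (0.51 log units; beyond the scatter). Compound 1 lies furthest away, with 1530 nM.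

The next compound, compound 4, has the structure `COC(=O)c1cccc(NC(=O)COc2ccc(C)cc2)c1`. It differs from compound 3 in one place: methyl in place of 1,1,3,3-tetramethylbutyl on an aromatic carbon. Among the measured compounds shown here, no measured step bears on this change; the only measured step, from compound 2 to compound 3, concerns a different position on a different ring, so nothing here shows how this assay responds to shortening this group. The estimate for compound 4 therefore rests on compound 3 alone and carries a wide range, leaning towards a higher number. The expected step is a 3.4-fold higher number from compound 3 to compound 4 (0.53 log units; beyond the scatter). Compound 4 is estimated at 30000 nM, within 8000 nM to 120000 nM.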

Compound 4, half-maximal inhibitory concentration: > 40000 nM
Compound 4: no number, only a limit; the forecaster's own chance of this, stated with the estimate: 35%; at least 1.3-fold (0.12 log units) between middle value and limit.
By their numbers in this assay, from the lowest: compound 1; then compound 3; then compound 2. At a limit, above all of these: compound 4.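

Every earlier compound carried the 1,1,3,3-tetramethylbutyl group, so none of them could show whether this position matters; cutting the group down to methyl now gives an at least 4.4-fold higher number from compound 3 to compound 4 (0.65 log units; beyond the scatter) in this assay. Compound 4 gives only a limit and not a number, so the size of this step is a minimum: the limit of > 40000 nM in this assay, at which 1 of the 4 values shown sits.

For this pair, then, the large group cannot be reduced to methyl without weakening inhibition beyond the usual scatter.

The compounds shown do not tell whether an intermediate group, such as a tert-butyl or an ethyl, or a ring such as cyclohexyl, would keep the inhibition of compound 3. On these data alone, it also remains open whether the same change would weaken inhibition to a similar degree in compound 1, which has a trifluoromethyl group on its other ring.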